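Removing an Ester from a Sulfonyl-Bearing Core

This account rests on a few compounds, and the source may have more. Where it says the series, first, only, none or still open, it means among the compounds named here.

Compound 1, with the structure `CCOC(=O)C1CCN(c2c(S(=O)(=O)c3ccccc3)cnc3ccccc23)CC1`, carries an ethoxycarbonyl group on the saturated ring that sits on the shared core. In an assay on isolated protein for displacement of a labelled ligand from metabotropic glutamate receptor 5 (Homo sapiens), with a stated time of 60 min (a higher number here means a weaker inhibitor, a lower number a stronger inhibitor), compound 1 gives "not determined" (no result reported), so no number places it on the scale. The only measured reference here is compound 2, with the structure `Cc1ccc2ncc(S(=O)(=O)c3cccc(F)c3)c(N3CCC(C)CC3)c2c1`, which in this assay gives 103 nM.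

The step to compound 3, with the structure `O=S(=O)(c1ccccc1)c1cnc2ccccc2c1N1CCCCC1`, is a single change: hydrogen in place of ethoxycarbonyl on a saturated ring carbon. Since compound 1 has no value, the size and direction of the step in this assay cannot be set against a starting number; the loss of the ethoxycarbonyl group can only be judged by comparing compound 3 with compound 2, whose saturated ring is also without that group.

With that reference in mind, compound 3 is expected to give about 200 nM in this assay, with a plausible range from 60 nM to 700 nM, placing it near compound 2.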

Compound 3, inhibition constant: 307 nM
Estimate against measurement, compound 3: 1.5-fold (0.19 log units) below, within the range that was stated.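

In this assay, compound 1 has no number to start from, and compound 3 differs from compound 2 in more than one place, so no step can be read among these compounds. From the compounds shown here alone, what removing the ethoxycarbonyl group does to the binding value stays open. No measurement shown here offers an explanation for the value of compound 3.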